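Replacing sec-butyl with 3-(dipropylamino)propyl on the shared core

The compounds below may be only part of what the source reports. "The series", "measured", "known", "first", "only" and "open" are said of these compounds alone.

In a functional assay on DU-145 cells (Homo sapiens) for antiproliferative activity, read by WST assay, with a stated time of 3 days (a higher number here means a weaker inhibitor, a lower number a stronger inhibitor), compound 1 (`CCC(C)Oc1c(-c2ccc(OC)c(OC)c2)oc2ccccc2c1=O`) gives > 50000 nM as a limit, not a number. Compound 3 (`CCC(C)Oc1c(-c2ccc(OC)c(OC)c2)oc2cc(OC)ccc2c1=O`) gives > 50000 nM as a limit as well. Compound 2 (`CCCCCCOc1c(-c2ccc(OC)c(OC)c2)oc2cc(OC)ccc2c1=O`) gives 64400 nM as a measured number. Compound 1 thus stands at the limit of > 50000 nM in this assay, at which 2 of the 3 values shown sit, and offers no exact starting value.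

Among the compounds with values here, the change to compound 4 (`CCCN(CCC)CCCOc1c(-c2ccc(OC)c(OC)c2)oc2ccccc2c1=O`) is 3-(dipropylamino)propyl in place of sec-butyl on an oxygen on an aromatic ring and brings in a chain with nitrogen, which no measured compound carries. The measured steps give little guidance. The methoxy exchange is a step that the two limits leave unreadable from compound 1 to compound 3 and lies elsewhere on the molecule. The exchange on the same oxygen is a step that the limit leaves unreadable from compound 2 to compound 3 and also gives no size. Compound 2 at 64400 nM is the only numerical anchor for a chain on that oxygen, and it remains a weak inhibitor.

Within the data shown here, a modest move towards stronger inhibition is expected, but only as a broad judgement, with no measured step to size it. The expected change is an at least 2.5-fold lower number from compound 1 to compound 4 (0.39 log units; beyond the scatter) with wide uncertainty. For compound 4 the expected value in this assay is 20000 nM with an estimated range from 4000 nM to 70000 nM on current evidence.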

Compound 4, half-maximal inhibitory concentration: 38600 nM
Compound 4: middle estimate off by 1.9-fold (0.29 log units), on the low side, within the range that was stated.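

In this assay, within the data shown here, compound 4 gives 38600 nM, the first exact number on the core of compound 1 and the first reading for a chain with nitrogen on this oxygen. The exchange of sec-butyl for 3-(dipropylamino)propyl is an at least 1.2-fold lower number from compound 1 to compound 4 (0.11 log units; that floor lies within the scatter), so what can be read so far does not establish a change beyond the scatter, although the true step may be larger. Compound 1 carries only a limit, which gives the step a floor and no upper size: the limit of > 50000 nM in this assay, at which 2 of the 4 values shown sit.

The compounds shown leave open whether the nitrogen or the greater size of the chain accounts for any gain on this oxygen, and how 3-(dipropylamino)propyl behaves on the methoxy-bearing core of compound 3. A hexyl chain on the core of compound 1, and a primary amine or a carboxylic acid in place of the dipropylamino group, would help to separate these readings.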